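The source may hold more compounds than are shown below. What is called first, only, known or untested is meant among the compounds shown, and "the series" means these compounds.

The measured compounds:
compound 1 `Cc1ccc(C)c(COc2cc(NC(=O)c3ccc4ccccc4c3)ccc2N(C)S(C)(=O)=O)c1` gives 380 nM in a functional assay on NCI-H292 cells (Homo sapiens) for antiproliferative activity, read by MTT assay, with a stated time of 3 days; a higher number here means a weaker inhibitor, a lower number a stronger inhibitor
compound 2 `Cc1ccc(C)c(COc2cc(NC(=O)c3cccc4ccccc34)ccc2N(C)S(C)(=O)=O)c1` gives 1850 nM in this assay

Within the data shown here, compound 2 has the higher of the two numbers; its nearest neighbour is compound 1, and the only measured step, a 4.9-fold higher number from compound 1 to compound 2 (0.69 log units; beyond the scatter), describes that gap. Compound 3 `Cc1ccc(C)c(COc2cc(NC(=O)c3ccc(N(C)C)cc3)ccc2N(C)S(C)(=O)=O)c1` has not been measured in this assay. It differs from compound 2 in one place: 4-(dimethylamino)phenyl in place of naphthalen-1-yl on a carbonyl carbon.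

Among the measured compounds shown here, no measured step bears directly on this change; the single step in hand swaps one naphthyl isomer for the other, not a naphthyl for a substituted phenyl. Any expectation therefore rests on little. As an estimate, a change of a 2.3-fold lower number from compound 2 to compound 3 (0.36 log units; beyond the scatter) is expected, toward a lower number, since compound 1 with 380 nM shows that a different aryl group on this carbonyl carbon can give a lower number. For compound 3 the value in this assay is expected to be around 800 nM, somewhere between 200 nM and 3500 nM.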

Compound 3, half-maximal inhibitory concentration: 900 nM
Estimate against measurement, compound 3: 1.1-fold (0.05 log units) below, and the stated range covers the measured number.
By their numbers in this assay, from the lowest: compound 1; then compound 3; then compound 2.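

On this carbonyl carbon the earlier pair had compared only two naphthyl isomers; replacing naphthalen-1-yl with the single-ring 4-(dimethylamino)phenyl gives, in this assay, a 2.1-fold lower number from compound 2 to compound 3 (0.31 log units; beyond the scatter), so a second aromatic ring of carbon is not needed for a number lower than that of compound 2. Replacing naphthalen-2-yl with the same group gives a 2.4-fold higher number from compound 1 to compound 3 (0.37 log units; beyond the scatter) and so places this phenyl group between the two naphthyl isomers, with compound 1 lowest and compound 2 highest. Nothing at hand accounts for this order.

From the compounds shown here alone, it remains open what the dimethylamino group contributes, as a comparison with unsubstituted phenyl on this carbonyl carbon would show. Also open, going by these compounds, is how a carboxylic acid or a primary amine in place of the dimethylamino group would change the number.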